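The source may report more compounds than this note shows. Statements on the series, on what has been measured and on what is new or still open speak of the compounds shown alone.

In a functional assay on HCT-116 cells (Homo sapiens) for inhibition (on this read-out higher numbers stand for an effect only at larger amounts of compound and lower numbers for an effect already at smaller amounts), compound 1 (`COc1cc(N2CCN(Cc3ccccn3)CC2)ccc1Nc1nc(NC2CCCCC2)c2nc[nH]c2n1`) gives 89 nM and compound 2 (`COc1cc(N2CCC(C(=O)N3CCC(N(C)C)C3)CC2)ccc1Nc1nc(NC2CCCCC2)c2nc[nH]c2n1`) gives 77 nM and the two numbers lie within the usual scatter of each other. Compound 3 (`COc1cc(N2CCC(C(=O)N3CCOCC3)CC2)ccc1Nc1nc(NC2CCCCC2)c2nc[nH]c2n1`), not yet measured, differs from compound 2 in one place (morpholin-4-yl in place of 3-(dimethylamino)pyrrolidin-1-yl on a carbonyl carbon): morpholin-4-yl in place of 3-(dimethylamino)pyrrolidin-1-yl on a carbonyl carbon. Going by the values given here, no measured pair differs in one place only, so the data give no direct measure of such a change. Compound 1 at 89 nM and compound 2 at 77 nM carry different side chains on the shared core and still sit within the scatter, which points to a modest step. In this assay a modest shift towards a higher number is expected, with an estimated step (a 1.7-fold higher number from compound 2 to compound 3 (0.23 log units; within the scatter)) not far beyond the scatter. For compound 3 the expected value is 130 nM with an estimated range of 45 nM to 400 nM in this measurement.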

Compound 3, half-maximal effective concentration: 130 nM
Compound 3: middle estimate and measured number agree at the digits printed, within the range that was stated.
By their numbers in this assay, from the lowest: compounds 2, 1 and 3 (each within the scatter of the next).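

In this assay, going by these compounds alone, putting morpholin-4-yl in place of 3-(dimethylamino)pyrrolidin-1-yl on a carbonyl carbon gives a 1.7-fold higher number from compound 2 to compound 3 (0.23 log units; within the scatter) and provides the first direct reading of a change at this place. The step shows that this position tolerates this exchange without a change that the assay can separate from the scatter, even though the five-membered ring with its 8 heavy atoms gives way to a six-membered ring with 6 heavy atoms and an oxygen. Nothing shown here explains this outcome.

On these data alone, whether a larger step can arise at this carbonyl carbon remains open, for example with piperazin-1-yl or a plain dimethylamino group there. The compounds shown also leave open how a carboxylic acid on the saturated ring carbon, in place of the whole amide, would read.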